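This account rests on a few compounds, and the source may have more. Where it says the series, first, only, none or still open, it means among the compounds named here.

Measured compounds:
compound 1, `O=C(CN1CCN(c2ccccc2)CC1)N1CCN(c2nnc(-c3ccc(Cl)cc3)c(-c3ccc(Cl)cc3)n2)CC1` — > 850000 nM
compound 2, `COc1cccc(N2CCN(CC(=O)N3CCN(c4nnc(-c5ccc(Cl)cc5)c(-c5ccc(Cl)cc5)n4)CC3)CC2)c1` — 202000 nM
compound 3, `COc1ccc(N2CCN(CC(=O)N3CCN(c4nnc(-c5ccc(Cl)cc5)c(-c5ccc(Cl)cc5)n4)CC3)CC2)cc1` — > 809000 nM

In an ADME assay on NIH3T3 cells (Mus musculus) for cytotoxicity, read by MTT assay, with a stated time of 24 h (on this read-out higher numbers stand for weaker inhibition and lower numbers for stronger inhibition), compound 3 gives only a limit, > 809000 nM. Compound 1 also sits at a limit, > 850000 nM. Compound 2 alone gives a number, 202000 nM, and the step of an at least 4.0-fold higher number from compound 2 to compound 3 (0.60 log units; beyond the scatter) is read against the limit (the limit of > 809000 nM in this assay, at which 1 of the 3 values shown sits). The step that the two limits leave unreadable from compound 1 to compound 3 stays unreadable. Compound 4, `O=C(CN1CCN(c2ccc(Cl)cc2)CC1)N1CCN(c2nnc(-c3ccc(Cl)cc3)c(-c3ccc(Cl)cc3)n2)CC1`, differs from compound 3 by chloro in place of methoxy on an aromatic carbon. Within the data shown here, no measured step covers chloro against methoxy, and the one readable step concerns where the methoxy sits rather than what replaces it, so compound 4 is expected to show a number no higher from compound 3 to compound 4 (the limit leaves the size open), that is, no step beyond the scatter. Compound 4 is therefore estimated at 800000 nM, between 300000 nM and 2000000 nM, most likely again reported as a limit.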

Compound 4, half-maximal inhibitory concentration: > 803000 nM
Compound 4 was reported as a limit; the forecaster's own chance of this, stated with the estimate: 70%; at least 1.0-fold (0.00 log units) between middle value and limit.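

In this assay compound 4 also gives only a limit, > 803000 nM. Among these compounds, the one readable step is an at least 3.9-fold higher number from compound 2 to compound 4 (0.59 log units; beyond the scatter), so a 4-chlorophenyl, like the 4-methoxyphenyl of compound 3, stands clear of the 3-methoxyphenyl of compound 2. The steps among compound 1, compound 3 and compound 4 cannot be read.

As far as these compounds go, how far chloro, methoxy and hydrogen at this place actually differ therefore stays open. Also open, from the compounds shown here alone, is whether an amine or a carboxylic acid at this place would bring the number down towards that of compound 2.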